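From Pyrazole to Phenyl on a Shared Core

A few compounds are considered here, and "the series" means these few. Any claim that something is new, unique, unknown or untested is made for them only; others in the source may bear on it.

Measured so far in a physicochemical assay for lipophilicity, at pH 7.4; a lower number here means a more polar compound, a higher number a more lipophilic compound

Compound 1 `Cc1nc(C)c(-c2nnc(-c3ccc(OC(C)C)c(Cl)c3)s2)s1` gives 7.76
Compound 2 `Cc1[nH]ncc1-c1nnc(-c2ccc(OC(C)C)c(Cl)c2)s1` gives 5.45
Compound 3 `CC(C)Oc1ccc(-c2nnc(-c3ccnn3C)s2)cc1Cl` gives 7.04

Compound 3 stands second highest of these three numbers, with compound 1 its nearest neighbour and compound 2 its furthest. Compound 4 `CC(C)Oc1ccc(-c2nnc(-c3ccccc3)s2)cc1Cl` has not yet been measured. It carries phenyl in place of 1-methyl-1H-pyrazol-5-yl on an aromatic carbon of the shared core (phenyl in place of 1-methyl-1H-pyrazol-5-yl on an aromatic carbon). Two measured steps involve the group that leaves. One exchange gave a number 0.72 log units lower from compound 1 to compound 3 (beyond the scatter), a modest step, when 1-methyl-1H-pyrazol-5-yl took the place of 2,4-dimethyl-1,3-thiazol-5-yl. The other gave a number 1.59 log units higher from compound 2 to compound 3 (beyond the scatter), a large step, when it took the place of 5-methyl-1H-pyrazol-4-yl. That second exchange joins two pyrazoles, so it is the weaker guide here. For the measured compounds named here, no measured compound carries phenyl at this place, and the first exchange, read in reverse, is the closest available comparison. A modest rise is therefore expected. The step expected in this assay is a number 0.56 log units higher from compound 3 to compound 4 (beyond the scatter), which would be of similar size to the first exchange. Compound 4 is estimated at 7.6 (expected range 7.2 to 8.1).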

Compound 4, distribution coefficient: 8.65
For compound 4 the middle estimate is 1.05 log units below the measured one, outside the stated range (above it).
By their numbers in this assay, from the lowest: compound 2; then compound 3; then compound 1; then compound 4.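

In this assay, putting phenyl in place of 1-methyl-1H-pyrazol-5-yl on an aromatic carbon of the shared core gave a number 1.61 log units higher from compound 3 to compound 4 (beyond the scatter), showing that this position can respond strongly even when the entering and leaving rings have the same count of heavy atoms. Phenyl also exceeded the two other groups tested here, with a number 0.89 log units higher from compound 1 to compound 4 (beyond the scatter) against 2,4-dimethyl-1,3-thiazol-5-yl and a number 3.20 log units higher from compound 2 to compound 4 (beyond the scatter) against 5-methyl-1H-pyrazol-4-yl, so among the four compounds the carbon-only ring gives the highest number and 2,4-dimethyl-1,3-thiazol-5-yl no longer marks the top of the series. No available evidence accounts for the size of these steps.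

The compounds shown do not separate the change from a five-membered to a six-membered ring from the removal of the ring nitrogens and their hydrogen-bond acceptors, since these differences arrive together in phenyl. They also leave open how the number would move with a pyridine ring at this place, or with a phenyl ring carrying an amine or a carboxylic acid.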